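A Methyl Group Added to Compound 2

The source may hold more compounds than are shown below. What is called first, only, known or untested is meant among the compounds shown, and "the series" means these compounds.

In an assay on the whole organism (plasma, strain Sprague-Dawley) for inhibition of Dipeptidyl peptidase 4 (Rattus norvegicus), with a stated time of 6 h, at a dose of 1 mg/kg by the oral route (a higher number here means more inhibition at the dose given (going by the name of the read-out), a lower number less inhibition), compound 1 `CCN(C)C(=O)[C@H]1C[C@@H](C(=O)N2CCC[C@H]2C#N)N[C@H]1C` gives 92%. Compound 2 `N#C[C@@H]1CCCN1C(=O)[C@@H]1C[C@H](C(=O)N2CCCCC2)CN1` gives 84% in this assay, and compound 3 `CCN(C)C(=O)[C@@H]1CN[C@H](C(=O)N2CCC[C@H]2C#N)C1` gives 71% in this assay. The two cores differ in that compound 2 carries piperidin-1-yl in place of ethyl(methyl)amino on a carbonyl carbon; this gave a number 13 percentage points lower from compound 2 to compound 3 (beyond the scatter). Adding a methyl, (methyl in place of hydrogen on a saturated ring carbon), gave a number 21 percentage points higher from compound 3 to compound 1 (beyond the scatter). Compound 4 `C[C@@H]1N[C@H](C(=O)N2CCC[C@H]2C#N)C[C@@H]1C(=O)N1CCCCC1` carries the same kind of change on compound 2, (methyl in place of hydrogen on a saturated ring carbon); the place differs only in that the neighbouring ring atom bears a group of 8 heavy atoms rather than an ethyl(methyl)carbamoyl group (6 heavy atoms). The step is expected to be a number 7 percentage points higher from compound 2 to compound 4 (within the scatter) because the same kind of change gave a number 21 percentage points higher from compound 3 to compound 1 (beyond the scatter), though with less room above the starting point. Compound 4 is therefore expected to reach 91% in this assay, plausibly between 80% and 98%.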

Compound 4, a percentage reported as inhibition, in the whole organism at one dose (the size of the read-out at that dose, not a potency): 91%
Estimate against measurement, compound 4: no gap at the digits printed, within the range that was stated.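

In this assay the methyl gives a number 7 percentage points higher from compound 2 to compound 4 (within the scatter), and this step does not differ from the one seen on the other core: the same change on two cores in this assay, a number 21 percentage points higher (beyond the scatter) from compound 3 to compound 1 and a number 7 percentage points higher (within the scatter) from compound 2 to compound 4, 14 percentage points apart, within the scatter of two such steps. Setting piperidin-1-yl in place of ethyl(methyl)amino on the methylated core gives a number 1 percentage points lower from compound 1 to compound 4 (within the scatter), and this step likewise agrees with its counterpart: the same change on two cores in this assay, a number 13 percentage points lower (beyond the scatter) from compound 2 to compound 3 and a number 1 percentage points higher (within the scatter) from compound 4 to compound 1, 14 percentage points apart, within the scatter of two such steps. Both changes therefore carry across these two cores within the scatter, but two pairs of compounds neither fix the size of either step nor show that it would hold on any other core.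

The compounds shown leave open what an ethyl or a hydroxymethyl group would do on that ring carbon in place of the methyl. They also leave open how a morpholin-4-yl group would compare on the carbonyl carbon.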